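A few compounds are considered here, and "the series" means these few. Any claim that something is new, unique, unknown or untested is made for them only; others in the source may bear on it.

Compound 1, `Oc1ccc(-c2cc(-c3cccs3)nc(-c3ccccc3Cl)c2)cc1`, was tested in a functional assay on T47D cells (Homo sapiens) for cytotoxicity, read by CCK-8 assay and cell counting, with a stated time of 2 days (on this read-out higher numbers stand for weaker inhibition and lower numbers for stronger inhibition), where compound 1 gives 5870 nM. Two close relatives were measured in the same way: compound 2, `Oc1ccc(-c2cc(-c3ccco3)nc(-c3ccccc3Cl)c2)cc1`, gives 5480 nM, and compound 3, `Oc1ccc(-c2cc(-c3cccc(Cl)c3)nc(-c3cccs3)c2)cc1`, gives 5350 nM. Compound 1 thus stands at the top edge of the three numbers, but the numbers of compounds 2 and 3 both sit inside the scatter of it: the step of a 1.1-fold lower number from compound 1 to compound 2 (0.03 log units; within the scatter) and the step of a 1.1-fold lower number from compound 1 to compound 3 (0.04 log units; within the scatter) are each too small to count as a change. Compound 4, `Oc1cccc(-c2cc(-c3cccs3)nc(-c3ccccc3Cl)c2)c1`, is the next compound, and it differs from compound 1 in that (3-hydroxyphenyl in place of 4-hydroxyphenyl on an aromatic carbon). Neither measured step bears directly on this change, since both alter the thiophen-2-yl or the 2-chlorophenyl group and leave the hydroxyphenyl group untouched; all the same, both steps were within the scatter, so compound 4 is expected to show a step of a 1.0-fold higher number from compound 1 to compound 4 (0.01 log units; within the scatter), no larger than the scatter. Compound 4 is therefore estimated at 6000 nM, within a range from 2500 nM to 15000 nM.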

Compound 4, half-maximal inhibitory concentration: 3990 nM
Beside the measured number, compound 4's estimate is 1.5-fold (0.18 log units) above it; measured number inside the range.
By their numbers in this assay, from the lowest: compounds 4, 3, 2 and 1 (each within the scatter of the next).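

This is the first change shown at the hydroxyphenyl group, which sits opposite the ring nitrogen, as compounds 2 and 3 altered only the other two groups. In this assay, moving the hydroxyl to give 3-hydroxyphenyl in place of 4-hydroxyphenyl produces a 1.5-fold lower number from compound 1 to compound 4 (0.17 log units; within the scatter), so this change of attachment, with the atoms unchanged, has no readable effect, and every single-place step shown so far stays within the scatter. Nothing shown offers an explanation for this result.

Going by these compounds, it remains open whether this group needs its hydroxyl at all, and whether an unsubstituted phenyl or a methoxyphenyl group would give a similar number. On these data alone, it is equally open whether an amine or a carboxylic acid in the hydroxyl's place would produce a step beyond the scatter.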